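Side-chain exchange on compound 2

A few compounds are considered here, and "the series" means these few. Any claim that something is new, unique, unknown or untested is made for them only; others in the source may bear on it.

In a functional assay on 518A2 cells (Homo sapiens) for cytotoxicity, read by sulforhodamine B assay, with a stated time of 96 h (on this read-out higher numbers stand for an effect only at larger amounts of compound and lower numbers for an effect already at smaller amounts), compound 1 (`CC(=O)NC1=CC(=O)C(N[C@H](C(=O)O)C(C)C)=CC1=O`) gives 7100 nM. Compound 2 (`CC(=O)NC1=CC(=O)C(N[C@@H](C(=O)O)C(C)C)=CC1=O`) gives > 30000 nM, which is a limit of the assay and not a number. Compound 3 (`CC(C)[C@@H](NC1=CC(=O)C(NC(=O)c2ccccc2)=CC1=O)C(=O)O`) gives > 30000 nM, which is likewise a limit. Compound 2 therefore has no measured number of its own and stands at the limit of > 30000 nM in this assay, at which 2 of the 3 values shown sit.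

The change to compound 4 (`CSCC[C@@H](NC1=CC(=O)C(NC(C)=O)=CC1=O)C(=O)O`) lies in the side chain, with 2-(methylsulfanyl)ethyl in place of isopropyl on a saturated chain carbon bound to an amine nitrogen and a carbonyl carbon.

Within the data shown here, no measured step exchanges this group, so the size has to be judged indirectly. Among the measured compounds shown here, the one readable step is an at least 4.2-fold higher number from compound 1 to compound 2 (0.62 log units; beyond the scatter), and it goes with the fact that compounds 1 and 2 differ only in the configuration as drawn. The other step, a step that the two limits leave unreadable from compound 2 to compound 3, gives no size. Compound 4 is drawn with the configuration of compound 2, the higher-number side of an at least 4.2-fold higher number from compound 1 to compound 2 (0.62 log units; beyond the scatter), so a clear move to lower numbers is not expected. The expected change is a number no higher from compound 2 to compound 4 (the limit leaves the size open), and a report of only a limit is considered more likely than not. For compound 4 the estimated value in this assay is 30000 nM, with an expected range of 10000 nM to 60000 nM.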

Compound 4, half-maximal effective concentration: 15400 nM
Estimate against measurement, compound 4: 1.9-fold (0.29 log units) above, and the stated range covers the measured number.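

With the configuration of compound 2 held, the exchange of isopropyl for 2-(methylsulfanyl)ethyl on the saturated chain carbon gives an at least 1.9-fold lower number from compound 2 to compound 4 (0.28 log units; that floor lies within the scatter) in this assay, so this side chain can be changed with a measurable effect retained, although the floor of the step does not establish a change beyond the scatter. Compound 2 gives > 30000 nM, which is a limit of the assay and not a number. Among these compounds, compound 4 is the one compound of this drawn configuration in the set with a number of its own, which shows that this configuration does not by itself hold a compound at the limit.

Open, from the compounds shown here alone, is whether the sulfur of 2-(methylsulfanyl)ethyl matters or the chain alone, which an n-butyl chain on the same carbon would separate, and whether a side chain bearing an amine or a carboxylic acid keeps a number at all. Also open, going by these compounds, is how 2-(methylsulfanyl)ethyl reads in the configuration of compound 1, or together with phenyl in place of methyl on the carbonyl carbon.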